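Methyl on the nitrogen of compound 3

The compounds below may be only part of what the source reports. "The series", "measured", "known", "first", "only" and "open" are said of these compounds alone.

Measured in a functional assay on Caco-2 cells (Homo sapiens) for cytotoxicity, read by MTT assay, with stated times of 6 h and 48 h; on this read-out lower numbers stand for stronger inhibition and higher numbers for weaker inhibition:
- compound 1 `Cn1c(/C=C/C(=O)c2ccccc2)cc(Br)c1Br`: >= 100000 nM
- compound 2 `O=C(/C=C/c1cc(Br)c(Br)[nH]1)c1ccccc1`: >= 100000 nM
- compound 3 `O=c1cc(-c2cc(Br)c(Br)[nH]2)oc2ccccc12`: >= 100000 nM

All three entries are limits, not numbers. For compound 3 the entry >= 100000 nM is likewise only a limit.

Compound 4 `Cn1c(-c2cc(=O)c3ccccc3o2)cc(Br)c1Br` differs from compound 3 by methyl in place of hydrogen on an aromatic nitrogen. Among the compounds with values here, the one measured step of this kind runs the opposite way, a step that the two limits leave unreadable from compound 1 to compound 2, and gives no size. The series offers only (the limit of >= 100000 nM in this assay, at which 3 of the 3 values shown sit). No step beyond the scatter is therefore expected in this assay, in either direction. The expected step is a number no higher from compound 3 to compound 4 (the limit leaves the size open). For compound 4 the estimated value is 100000 nM, with an expected range from 50000 nM to 200000 nM.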

Compound 4, half-maximal inhibitory concentration: >= 100000 nM
Compound 4 gave a limit, no number; the forecaster's own chance of this, stated with the estimate: 90%; the middle value sits exactly at the limit.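

In this assay, within the data shown here, compound 3 and compound 4 both give limits, not numbers, and no step between them can be read. The compounds shown leave open how far any change on the shared core moves the read-out, because all of them stop at the same point: the limit of >= 100000 nM in this assay, at which 4 of the 4 values shown sit.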